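Removing the methoxy from compound 2

The compounds below may be only part of what the source reports. "The series", "measured", "known", "first", "only" and "open" are said of these compounds alone.

Going by the values given here, the series so far holds compound 1 `[SeH]c1nc([SeH])c2ccccc2n1` and compound 2 `COc1ccc(CNc2nc(SC)nc3ccccc23)cc1`, both tested in a functional assay on MCF7 cells (Homo sapiens) for cytotoxicity, read by MTT assay, with a stated time of 72 h; on this read-out higher numbers stand for lower toxicity in this test and lower numbers for higher toxicity in this test. Compound 1 gives only a limit there, > 100000 nM. Compound 2 likewise returns only a limit in this assay, > 100000 nM. Among the compounds with values here, no step between measured compounds exists, since both sit at the limit of > 100000 nM in this assay, at which 2 of the 2 values shown sit; where compound 2 stands is therefore told by that limit alone, with no number to rank it against compound 1.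

Compound 3 `CSc1nc(NCc2ccccc2)c2ccccc2n1` is the next compound to be measured. Its difference from compound 2 is hydrogen in place of methoxy on an aromatic carbon. Compound 2 shows nothing but the limit in this assay. No step beyond the usual scatter is therefore expected, and the expected step is a step that the limit leaves unreadable from compound 2 to compound 3. Compound 3 is expected to give about 150000 nM in this assay, within a range of 50000 nM to 400000 nM, most probably again reported as a limit rather than a number.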

Compound 3, concentration lethal to 50% of the cells: > 100000 nM
Compound 3: a limit, no number (the forecaster's own chance of this, stated with the estimate: 80%); the middle value is on the limit's open side.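

No step from compound 2 to compound 3 can be read in this assay, because both give only a limit: the limit of > 100000 nM in this assay, at which 3 of the 3 values shown sit.

The compounds shown leave open whether hydrogen in place of methoxy changes the read-out at all, and what separates any of them in this assay.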